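A few compounds are considered here, and "the series" means these few. Any claim that something is new, unique, unknown or untested is made for them only; others in the source may bear on it.

Compound 1 `COc1cccc2c(OC(C)C)c(C(=O)Nc3nn[nH]n3)sc12`: > 100000 nM, a limit
Compound 2 `CC(C)Oc1c(C(=O)Nc2nn[nH]n2)sc2ccccc12`: > 100000 nM, a limit

Both compounds were tested in a functional assay for inhibition, with Homo sapiens as the target (a higher number here means a weaker inhibitor, a lower number a stronger inhibitor), and neither gave a number. Compound 2 stands at > 100000 nM, which is a limit of the assay. The whole record comes down to the limit of > 100000 nM in this assay, at which 2 of the 2 values shown sit.

Compound 3 `CC(C)Oc1c(C(=O)Nc2nn[nH]n2)sc2ccc(OCc3ccccc3)cc12` carries one change from compound 2: benzyloxy in place of hydrogen on an aromatic carbon. Among the measured compounds shown here, the only measured step that bears on it is a step that the two limits leave unreadable from compound 1 to compound 2. That step is also a change of substituent on an aromatic carbon, but it supplies neither a size nor a direction to carry over. No step beyond the scatter can therefore be expected in this assay, and compound 3 is expected to stay near the same limit. The expected change is a number no higher from compound 2 to compound 3 (the limit leaves the size open). Compound 3 is estimated at 100000 nM, with an expected range from 20000 nM to 300000 nM.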

Compound 3, half-maximal inhibitory concentration: > 100000 nM
Compound 3 ended at the assay's limit (the forecaster's own chance of this, stated with the estimate: 75%); the middle value sits exactly at the limit.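

Compound 2 and compound 3 both ended at a limit, so no step between them can be read, and the record stays as it was: the limit of > 100000 nM in this assay, at which 3 of the 3 values shown sit.

The compounds shown leave open whether hydrogen, methoxy or benzyloxy on the shared core makes any difference in this assay.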